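Moving a Methoxy Group on Two Related Cores

The compounds below may be only part of what the source reports. "The series", "measured", "known", "first", "only" and "open" are said of these compounds alone.

Compound 1, `COc1ccccc1NC(=O)Nc1cccc(CNc2ncnc3ccccc23)c1`, gives 39300 nM in a functional assay on MGC-803 cells (Homo sapiens) for antiproliferative activity, read by MTT assay; on this read-out higher numbers stand for weaker inhibition and lower numbers for stronger inhibition.
Compound 2, `COc1ccc(NC(=O)Nc2cccc(CNc3ncnc4ccccc34)c2)cc1`, gives 27300 nM in this assay.
Compound 3, `COc1ccccc1NC(=O)Nc1cccc(CNc2ncnc3cc(OC)c(OC)cc23)c1`, gives 7710 nM in this assay.

Compounds 1 and 2 are built on one core, while compound 3 and the unmeasured compound 4, `COc1ccc(NC(=O)Nc2cccc(CNc3ncnc4cc(OC)c(OC)cc34)c2)cc1`, are built on another; how the two cores differ is not broken down here. Compound 3 has the lowest number of the three measured, and its gaps to compound 2 and to compound 1 both lie beyond the usual scatter.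

The change from compound 1 to compound 2 is 4-methoxyphenyl in place of 2-methoxyphenyl on an amide-type nitrogen. It produced a 1.4-fold lower number from compound 1 to compound 2 (0.16 log units; within the scatter), a step that does not stand out from repeat measurements. The change from compound 3 to compound 4 is 4-methoxyphenyl in place of 2-methoxyphenyl on an amide-type nitrogen, the same change at the same place on the other core.

Because the earlier step was a 1.4-fold lower number from compound 1 to compound 2 (0.16 log units; within the scatter), a step of similar size, a 1.4-fold lower number from compound 3 to compound 4 (0.14 log units; within the scatter), is expected for compound 4. Compound 4 is therefore estimated at 5600 nM in this assay, most likely between 2500 nM and 13000 nM.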

Compound 4, half-maximal inhibitory concentration: 12300 nM
Compound 4: middle estimate off by 2.2-fold (0.34 log units), on the low side; the range from low to high includes it.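

In this assay, placing 4-methoxyphenyl where 2-methoxyphenyl stood on the amide-type nitrogen gave a 1.6-fold higher number from compound 3 to compound 4 (0.20 log units; within the scatter), so on this core too the change does not stand out from repeat measurements. Set beside the earlier step, the result gives no sign that the two cores respond differently, and the opposite directions of the two steps should not be read as a reversal: the same change on two cores in this assay, a 1.4-fold lower number (0.16 log units; within the scatter) from compound 1 to compound 2 and a 1.6-fold higher number (0.20 log units; within the scatter) from compound 3 to compound 4, 2.3-fold (0.36 log units) apart, within the scatter of two such steps. Among the compounds shown here, this shows only that the change stayed within the scatter on both cores; it does not show that the position of the methoxy group is without effect in general, and a pair of such small steps is a weak test of whether a change carries from one core to another.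

The compounds shown leave open whether other groups in this place, such as a plain phenyl, a chlorophenyl or a phenyl bearing a carboxylic acid, would give steps beyond the scatter. They also leave open whether any such larger step would carry over between the two cores.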